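A Bromine for a Fluorine on the Urea Nitrogen

The compounds below may be only part of what the source reports. "The series", "measured", "known", "first", "only" and "open" are said of these compounds alone.

Compound 1 `O=C(Nc1cccc(F)c1)N[C@H]1CC[C@H](Oc2ccc(F)cc2)CC1` gives 8300 nM in a functional assay on CRL2813 cells (Homo sapiens) for cytotoxicity, read by sulforhodamine B assay, with a stated time of 5 days (a lower number here means a stronger inhibitor, a higher number a weaker inhibitor), the highest of the two numbers measured. Going by the values given here, compound 2 `O=C(Nc1cccc(C(F)(F)F)c1)N[C@H]1CC[C@H](Oc2ccc(C(F)(F)F)cc2)CC1` gives 460 nM in this assay, a far lower number, but it differs from compound 1 at both ends, so no single step is known. Compound 3 `O=C(Nc1ccccc1Br)N[C@H]1CC[C@H](Oc2ccc(F)cc2)CC1` remains unmeasured and differs from compound 1 in one place: 2-bromophenyl in place of 3-fluorophenyl on an amide-type nitrogen. Starting from compound 1, compound 3 is expected to show a modestly lower number, a step of a 1.8-fold lower number from compound 1 to compound 3 (0.27 log units; within the scatter) that may stay within the scatter. The estimate for compound 3 is 4500 nM, ranging from 1500 nM to 13000 nM.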

Compound 3, half-maximal inhibitory concentration: 7700 nM
Beside the measured number, compound 3's estimate is 1.7-fold (0.23 log units) below it; low and high end bracket the measured number.
By their numbers in this assay, from the lowest: compound 2; then compounds 3 and 1 (each within the scatter of the next).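

In this assay, going by these compounds alone, placing 2-bromophenyl where compound 1 carries 3-fluorophenyl on the amide-type nitrogen gives a 1.1-fold lower number from compound 1 to compound 3 (0.03 log units; within the scatter), the first single change that can be read at this position. In this one pair, the halogen and its ring position change together with no difference beyond the scatter. Nothing measured here offers an explanation for this result. Compound 2 differs from compound 1 at both ends, so its steps cannot be read, and the separate contributions of bromine and ring position remain unresolved. On these data alone, whether an amine or a carboxylic acid on this phenyl ring would alter the number also stays open.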